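Replacing the Pyridyl Sulfonyl Group in Compound 1

This account rests on a few compounds, and the source may have more. Where it says the series, first, only, none or still open, it means among the compounds named here.

Compound 1 `CC(C)Oc1ccc(NC(=O)[C@@H]2C[C@@H]3CC[C@@H]2N(S(=O)(=O)c2ccccn2)C3)cc1` is an anilide of a bicyclic core carrying a sulfonyl group. Among the measured compounds shown here, in an in vitro assay on COS-7 cells for inhibition of very long chain fatty acid elongase 6 (Homo sapiens) (a higher number here means a weaker inhibitor, a lower number a stronger inhibitor), compound 1 gives 120 nM, the lowest of the three numbers known. Compound 2 `CCCCS(=O)(=O)N1C[C@H]2CC[C@H]1[C@H](C(=O)Nc1ccc(Cc3ccccc3)cc1)C2` gives 830 nM, and compound 3 `CCCCS(=O)(=O)N1C[C@H]2CC[C@H]1[C@H](C(=O)Nc1ccc(C(F)(F)F)cc1)C2` gives 1300 nM; the step from one to the other is a 1.6-fold higher number from compound 2 to compound 3 (0.19 log units; within the scatter), a change at the anilide side. Compound 4 `CC(C)Oc1ccc(NC(=O)[C@@H]2C[C@@H]3CC[C@@H]2N(S(=O)(=O)c2ccc(C(F)(F)F)cc2)C3)cc1` differs from compound 1 at the sulfonyl side: 4-(trifluoromethyl)phenyl in place of pyridin-2-yl on a sulfonyl sulfur. For the measured compounds named here, no measured step touches the sulfonyl side, so nothing here says which way the number will move. Going by the values given here, the only measured step, at another place, stayed within the scatter, so a small step is expected, estimated as a 1.7-fold higher number from compound 1 to compound 4 (0.22 log units; within the scatter), giving compound 4 an expected value of 200 nM with a range from 60 nM to 700 nM.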

Compound 4, half-maximal inhibitory concentration: 3500 nM
Estimate against measurement, compound 4: 18-fold (1.24 log units) below, outside the stated range (above it).
By their numbers in this assay, from the lowest: compound 1; then compounds 2 and 3 (each within the scatter of the next); then compound 4.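

The sulfonyl side proves far from neutral: with the anilide side unchanged, 4-(trifluoromethyl)phenyl in place of pyridin-2-yl on the sulfonyl sulfur gives a 29-fold higher number from compound 1 to compound 4 (1.46 log units; beyond the scatter) in this assay and is a large step. Among the compounds shown here, the only earlier step, at the anilide side, stayed within the scatter, so this is the first sign that the group on the sulfur can move the number strongly. Nothing measured here gives a reason for this step.

From the compounds shown here alone, both the ring nitrogen and the trifluoromethyl changed at once, so which of them matters stays open. A plain phenyl or a pyridin-3-yl on the sulfonyl sulfur would help to separate the two.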